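Ethylcarbamoyl to hydroxymethyl on the sugar of compound 2

The source may hold more compounds than are shown below. What is called first, only, known or untested is meant among the compounds shown, and "the series" means these compounds.

Measured compounds:
compound 1, `CNc1nc(-n2cc(-c3ccccn3)nn2)nc2c1ncn2[C@@H]1O[C@H](CO)[C@@H](O)[C@H]1O`, 1970 nM
compound 2, `CCCCc1cn(-c2nc(NC)c3ncn([C@@H]4O[C@H](C(=O)NCC)[C@@H](O)[C@H]4O)c3n2)nn1`, 750 nM

Going by the values given here, in an assay on CHO cells for displacement of a labelled ligand from adenosine receptor A1 (Homo sapiens) (on this read-out lower numbers stand for stronger inhibition and higher numbers for weaker inhibition), compound 2 gives the lower of the two numbers known so far, 750 nM, while compound 1 gives 1970 nM; the gap between the two lies beyond the scatter. Compound 3, `CCCCc1cn(-c2nc(NC)c3ncn([C@@H]4O[C@H](CO)[C@@H](O)[C@H]4O)c3n2)nn1`, is not yet measured. It differs from compound 2 in one place: hydroxymethyl in place of ethylcarbamoyl on a saturated ring carbon. Among the compounds with values here, no measured pair in this set shows the same change, so the size of the step rests on the two numbers only; compound 1, which also carries the hydroxymethyl, gives the higher number, though it differs from compound 2 elsewhere as well. The step from compound 2 to compound 3 is expected to go toward weaker inhibition in this assay, by a 3.3-fold higher number from compound 2 to compound 3 (0.52 log units; beyond the scatter), beyond the scatter. For compound 3 the expected value in this assay is 2500 nM, with a range from 800 nM to 8000 nM.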

Compound 3, inhibition constant: 848 nM
Compound 3: middle estimate off by 2.9-fold (0.47 log units), on the high side; measured number inside the range.
By their numbers in this assay, from the lowest: compounds 2 and 3 (each within the scatter of the next); then compound 1.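

In this assay, hydroxymethyl in place of ethylcarbamoyl on the saturated ring carbon gives a 1.1-fold higher number from compound 2 to compound 3 (0.05 log units; within the scatter), so with butyl on the aromatic carbon the two groups cannot be told apart at this position. Butyl in place of pyridin-2-yl on an aromatic carbon gives a 2.3-fold lower number from compound 1 to compound 3 (0.37 log units; beyond the scatter), so of the two places where compound 1 and compound 2 differ, only this one shows a step beyond the scatter, and that step is modest. Nothing available explains either step.

The compounds shown leave open whether the two groups also match with pyridin-2-yl on the aromatic carbon, since compound 1 has no ethylcarbamoyl partner. They also leave open how a carboxylic acid on the saturated ring carbon, or a chain longer than butyl on the aromatic carbon, would read in this assay.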